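The source may report more compounds than this note shows. Statements on the series, on what has been measured and on what is new or still open speak of the compounds shown alone.

Working notes on the series. Of the compounds shown here, two of the shared core have numbers so far: compound 1 `C[C@@H](CNc1ccc(OC(F)(F)F)cc1)NC(=O)[C@@H](CC(=O)N1CCOCC1)CC1CCCC1` and compound 2 `CC(C)[C@@H](CNc1ccc(OC(F)(F)F)cc1)NC(=O)[C@H](CCCc1ccccc1)CC(=O)N1CCOCC1`. In an assay on isolated protein for inhibition of cathepsin S (Homo sapiens) (a lower number here means a stronger inhibitor, a higher number a weaker inhibitor), compound 1 gives 31 nM, while compound 2 gives 14 nM, the lower of the two numbers, with the gap to compound 1 beyond the scatter. Compound 3 `CC(C)[C@@H](CNc1ccc(OC(F)(F)F)cc1)NC(=O)[C@@H](CC(=O)N1CCOCC1)CC1CCCCC1` is not yet measured; it differs from compound 2 by cyclohexyl in place of phenethyl on a saturated chain carbon, two bonds along the chain from a carbonyl carbon. For this assay the change is expected to be small, within the scatter or a slight move to a higher number, giving an estimated step of a 1.4-fold higher number from compound 2 to compound 3 (0.15 log units; within the scatter). Compound 3 is therefore estimated at 20 nM, with a range from 7 nM to 60 nM.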

Compound 3, inhibition constant: 11 nM
Compound 3: middle estimate off by 1.8-fold (0.26 log units), on the high side, and the stated range covers the measured number.
By their numbers in this assay, from the lowest: compounds 3 and 2 (each within the scatter of the next); then compound 1.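

At this position, on a saturated chain carbon, two bonds along the chain from a carbonyl carbon, cyclohexyl in place of phenethyl gives a 1.3-fold lower number from compound 2 to compound 3 (0.10 log units; within the scatter) in this assay. In this pair, the non-aromatic ring with fewer heavy atoms therefore serves as well as the aromatic group with its longer reach. No available data bear on why the two groups match.

Still open, from the compounds shown here alone, is how a longer chain ending in cyclohexyl would read at this position. Also open, going by these compounds, is whether an amine or a carboxylic acid on the ring would be accepted there.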